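A few compounds are considered here, and "the series" means these few. Any claim that something is new, unique, unknown or untested is made for them only; others in the source may bear on it.

Three compounds share one core and differ only in the aryl group carried on a nitrogen on an aromatic ring. Compound 1 `CCc1cccc(Nc2cc(NC(=O)Nc3cc(OC)cc(OC)c3)ncn2)c1` gives 27.7% in a functional assay on NCI-H1581 cells (Homo sapiens) for inhibition, read by MTT assay, with a stated time of 48 h, tested at 10 uM; on this read-out lower numbers stand for less inhibition and higher numbers for more inhibition at the one concentration tested (going by the name of the read-out). Compound 2 `COc1cc(NC(=O)Nc2cc(Nc3ccc(C)c(F)c3)ncn2)cc(OC)c1` gives 38% in this assay, and compound 3 `COc1cc(NC(=O)Nc2cc(Nc3ccc(OC)c(I)c3)ncn2)cc(OC)c1` gives 43% in this assay. Compound 3 therefore shows the highest of the three numbers, though its gap to compound 2 lies within the scatter, while its gap to compound 1 is beyond it.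

Compound 4 `COc1cc(NC(=O)Nc2cc(Nc3ccc(Br)cc3OC)ncn2)cc(OC)c1` is the next step from compound 3: 4-bromo-2-methoxyphenyl in place of 3-iodo-4-methoxyphenyl on a nitrogen on an aromatic ring.

All three measured steps change this same aryl group, so all bear on the change. The step of a number 10.3 percentage points higher from compound 1 to compound 2 (beyond the scatter) and the step of a number 15.3 percentage points higher from compound 1 to compound 3 (beyond the scatter) were modest, and the step of a number 5 percentage points higher from compound 2 to compound 3 (within the scatter) was within the scatter. Swapping one substituted phenyl ring for another at this place has thus moved the number by a modest amount at most. Since compound 4 keeps a halogen and a methoxy group on the ring, only at different places, the expectation is a step of a number 5 percentage points lower from compound 3 to compound 4 (within the scatter) that stays within the scatter, with no clear direction. Compound 4 is estimated to give 38% in this assay, expected to fall between 22% and 52%.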

Compound 4, a percentage reported as inhibition, at one concentration (the size of the read-out at that concentration, not a potency): 20.1%
The estimate for compound 4 lay 17.9 percentage points above the measured number; the whole stated range lies above it.
By their numbers in this assay, from the lowest: compounds 4 and 1 (each within the scatter of the next); then compounds 2 and 3 (each within the scatter of the next).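

In this assay, within the data shown here, this position proves more sensitive than the earlier compounds suggested: 4-bromo-2-methoxyphenyl in place of 3-iodo-4-methoxyphenyl gives a number 22.9 percentage points lower from compound 3 to compound 4 (beyond the scatter), the largest step seen so far, and the same group in place of 3-fluoro-4-methylphenyl gives a number 17.9 percentage points lower from compound 2 to compound 4 (beyond the scatter). The two groups in the first of these steps have the same counts of heavy atoms, hydrogen-bond donors and hydrogen-bond acceptors, so those counts do not separate them, and carrying a halogen and a methoxy group does not by itself secure the higher numbers. The step of a number 7.6 percentage points lower from compound 1 to compound 4 (within the scatter) also places the 4-bromo-2-methoxyphenyl compound level with the 3-ethylphenyl compound, which carries neither a halogen nor a methoxy group.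

No available data explain these differences. Open questions are whether the bromine or the different arrangement of the groups on the ring matters more, and how the number would respond to a phenyl ring bearing an amine or a carboxylic acid.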